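Swapping Fluoro for Methyl on Compound 3

The compounds below may be only part of what the source reports. "The series", "measured", "known", "first", "only" and "open" are said of these compounds alone.

In a functional assay on OVCAR-3 cells (Homo sapiens) for antiproliferative activity (on this read-out higher numbers stand for weaker inhibition of growth and lower numbers for stronger inhibition of growth), compound 3 `Cc1cc(C)c2c(O)cc(-c3cccc(F)c3)nc2n1` gives 18.2 nM and compound 1 `Cc1ccnc2nc(-c3cccc(Cl)c3)cc(O)c12` gives 31.6 nM, two values within the scatter of each other. Compound 2 `Cc1ccc2c(O)cc(-c3cccc(Cl)c3)nc2n1` gives < 10 nM, which is a limit and not a number. Compound 4 `Cc1cccc(-c2cc(O)c3c(C)cc(C)nc3n2)c1` has methyl in place of fluoro on an aromatic carbon, on a six-membered aromatic ring of carbon only, meta to a large group. Among the measured compounds shown here, no measured pair tests this swap, so in this assay no change beyond the scatter is expected. The expected move is a 1.1-fold higher number from compound 3 to compound 4 (0.04 log units; within the scatter). For compound 4 the estimated value is 20 nM. The expected range for compound 4 runs from 8 nM to 50 nM.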

Compound 4, concentration for 50% growth inhibition: 30200 nM
The estimate for compound 4 lay 1500-fold (3.18 log units) below the measured number; the whole stated range lies below it.
By their numbers in this assay, from the lowest: compounds 3 and 1 (each within the scatter of the next); then compound 4. At a limit, below all of these: compound 2.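

In this assay, the place meta to a large group on the six-membered aromatic ring proves highly sensitive: methyl in place of fluoro gives a 1700-fold higher number from compound 3 to compound 4 (3.22 log units; beyond the scatter), though each group is a single heavy atom. The earlier compounds shown here carry only fluoro or chloro here, so none showed what a methyl does at this place. Nothing shown here accounts for this loss. As far as these compounds go, whether other groups at this place, such as an amine or a methoxy group, fare as poorly stays open. So does whether an unsubstituted carbon here keeps the growth inhibition.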